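The source may report more compounds than this note shows. Statements on the series, on what has been measured and on what is new or still open speak of the compounds shown alone.

Measured in a functional assay on HEK293 cells for antagonist activity at proteinase-activated receptor 1 (Homo sapiens), read by FLIPR and calcium flux, with a stated time of 15 min; a higher number here means a weaker inhibitor, a lower number a stronger inhibitor:
compound 1 `C[C@H]1CC[C@@H]2[C@](C)(C=O)[C@H](O)CC[C@@]2(C)[C@@H]1/C=C/c1ccc(-c2cccc(F)c2)cn1` gives 1500 nM
compound 2 `C[C@@]12CC[C@@H](O)[C@@](C)(C3SCCS3)[C@H]1CC[C@H](C1SCCS1)[C@H]2/C=C/c1ccc(-c2cccc(F)c2)cn1` gives > 100000 nM, a limit of the assay
compound 3 `C[C@H]1CC[C@@H]2C(C)(C)[C@H](OS(C)(=O)=O)CC[C@@]2(C)[C@@H]1/C=C/c1ccc(-c2cccc(F)c2)cn1` gives 87000 nM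

Of the two numbers that are not limits, compound 3 holds the higher one. The gap between compound 3 and compound 1 lies well beyond the scatter of this assay. Compound 4 `CCCC(=O)O[C@@H]1CC[C@@]2(C)[C@H](/C=C/c3ccc(-c4cccc(F)c4)cn3)[C@@H](C)CC[C@@H]2C1(C)C` is not yet measured; it differs from compound 3 by propylcarbonyl in place of methylsulfonyl on an oxygen on a saturated carbon. Among the compounds with values here, no measured pair isolates this change, so the direction rests on judgement alone. Compound 4 is expected to come in somewhat lower than compound 3, by a step of a 2.9-fold lower number from compound 3 to compound 4 (0.46 log units; beyond the scatter), though a result within the scatter would not surprise. The estimate for compound 4 is 30000 nM, with a range of 5000 nM to 150000 nM.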

Compound 4, half-maximal inhibitory concentration: > 100000 nM
Compound 4 ended at the assay's limit; the forecaster's own chance of this, stated with the estimate: 25%; middle value at least 3.3-fold (0.52 log units) from the limit.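

On an oxygen on a saturated carbon, propylcarbonyl in place of methylsulfonyl gives, in this assay, an at least 1.1-fold higher number from compound 3 to compound 4 (0.06 log units; that floor lies within the scatter). Compound 4 stands at a limit of the assay, so only a floor for this step can be read, and the exchange brings no measurable gain in inhibition. That limit recurs among these compounds: the limit of > 100000 nM in this assay, at which 2 of the 4 values shown sit.

Going by these compounds, how far compound 4 truly lies from compound 3 stays open. Also open, on these data alone, is whether an acetyl group or a carbamate on this oxygen would give a number that can be read.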